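Exposure in rats across three small aromatic rings

A few compounds are considered here, and "the series" means these few. Any claim that something is new, unique, unknown or untested is made for them only; others in the source may bear on it.

Measured compounds:
- compound 1 `Cc1cn2c(-c3cn[nH]c3)cnc2c(Nc2cc(Cc3nccs3)ns2)n1`: 1540 ng.h/mL
- compound 2 `Cc1cn2c(-c3cn[nH]c3)cnc2c(Nc2cc(Cc3ncccn3)ns2)n1`: 701 ng.h/mL
- compound 3 `Cc1cn2c(-c3cn[nH]c3)cnc2c(Nc2cc(Cc3cnccn3)ns2)n1`: 58.4 ng.h/mL

All three compounds share one core and differ only in the small aromatic ring carried on a saturated chain carbon bound to an aromatic carbon. In an ADME assay on the whole organism for pharmacokinetics, with Rattus norvegicus as the target, with a stated time of 6 h, at a dose of 10 mg/kg by the oral route (on this read-out lower numbers stand for lower exposure and higher numbers for higher exposure at the dose given), compound 2 gives 701 ng.h/mL, the second highest of the three numbers. One step runs a 2.2-fold lower number from compound 1 to compound 2 (0.34 log units; beyond the scatter), and the step onward runs a 12-fold lower number from compound 2 to compound 3 (1.08 log units; beyond the scatter). Compound 4 `Cc1cn2c(-c3cn[nH]c3)cnc2c(Nc2cc(Cc3ncccc3C)ns2)n1` is the unmeasured member; the change from compound 2 is 3-methylpyridin-2-yl in place of pyrimidin-2-yl on a saturated chain carbon bound to an aromatic carbon.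

Going by the values given here, no measured step swaps in a ring with a single nitrogen, so the two steps above are the only guide. They show that exchanging this ring can move the number a little, as from compound 1 to compound 2, or a great deal, as from compound 2 to compound 3. The change in compound 4 is therefore expected to produce a step of a 1.3-fold higher number from compound 2 to compound 4 (0.11 log units; within the scatter), with a wide band of uncertainty. The estimate for compound 4 is 900 ng.h/mL, expected to lie between 150 ng.h/mL and 4000 ng.h/mL.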

Compound 4, area under the concentration-time curve: 644 ng.h/mL
For compound 4 the middle estimate is 1.4-fold (0.15 log units) above the measured one; measured number inside the range.
By their numbers in this assay, from the lowest: compound 3; then compounds 4 and 2 (each within the scatter of the next); then compound 1.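

In this assay, the 3-methylpyridin-2-yl ring, with one ring nitrogen and a methyl, cannot be told apart from the pyrimidin-2-yl ring, as shown by a 1.1-fold lower number from compound 2 to compound 4 (0.04 log units; within the scatter) and a difference within the scatter. The same ring still gives an 11-fold higher number from compound 3 to compound 4 (1.04 log units; beyond the scatter) and a 2.4-fold lower number from compound 1 to compound 4 (0.38 log units; beyond the scatter), so a six-membered ring here need not bring the low exposure of compound 3, while the 1,3-thiazol-2-yl ring of compound 1 stays ahead. No measurement shown here accounts for these differences.

The compounds shown include no plain pyridin-2-yl ring, so the separate contributions of the methyl and of the change in ring nitrogens stay open. Also open, on these data alone, is how a methoxy group or an amine on this ring, or a longer chain, would read.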